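A few compounds are considered here, and "the series" means these few. Any claim that something is new, unique, unknown or untested is made for them only; others in the source may bear on it.

Compound 1, `COc1cccc(F)c1-c1cccc2nc(Nc3ccccc3)oc12`, in an assay on BAF cells for inhibition of ribosomal protein S6 kinase alpha-2 (Mus musculus) (on this read-out lower numbers stand for stronger inhibition and higher numbers for weaker inhibition), gives the limit > 20000 nM.
Compound 2, `COc1cccc(F)c1-c1cccc2nc(Nc3cccc(S(N)(=O)=O)c3)oc12`, gives the limit > 20000 nM.
Compound 3, `COc1cc(Nc2nc3cccc(-c4ccccc4OC(F)(F)F)c3o2)cc(OC)c1OC`, gives the limit > 20000 nM.

All three values are limits of this assay, not numbers, as the limit of > 20000 nM in this assay, at which 3 of the 3 values shown sit, records. Among the measured compounds shown here, compound 3 therefore stands only at a limit, and the one measured step, a step that the two limits leave unreadable from compound 1 to compound 2, is unreadable for the same reason. Compound 4, `COc1cc(Nc2nc3cccc(-c4cccc5cn[nH]c45)c3o2)cc(OC)c1OC`, differs from compound 3 by 1H-indazol-7-yl in place of 2-(trifluoromethoxy)phenyl on an aromatic carbon. For the measured compounds named here, no measured step bears on this change in a readable way, so no direction can be expected beyond the scatter. The step from compound 3 to compound 4 is estimated as a step that the limit leaves unreadable from compound 3 to compound 4. Compound 4 is thus expected at 25000 nM, in a range from 3000 nM to 100000 nM, and most likely reported again only as a limit.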

Compound 4, half-maximal inhibitory concentration: 5700 nM
Compound 4: the middle estimate sits 4.4-fold (0.64 log units) above what was measured; the measured number falls inside the stated range.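

Putting 1H-indazol-7-yl in place of 2-(trifluoromethoxy)phenyl gives an at least 3.5-fold lower number from compound 3 to compound 4 (0.54 log units; beyond the scatter) in this assay and is the first readable change among these compounds, so this position on the shared core can move the read-out. The size of the step is only a minimum, because compound 3 stands at a limit: the limit of > 20000 nM in this assay, at which 3 of the 4 values shown sit.

The compounds shown leave open whether the nitrogen-bearing five-membered ring or simply the second ring matters, since the swap changes both at once. As far as these compounds go, how an indole, or an amine or carboxylic acid on the phenyl ring, would fare at this position also stays open.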